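Chloro for Methyl on a Biphenyl Propanamide

A few compounds are considered here, and "the series" means these few. Any claim that something is new, unique, unknown or untested is made for them only; others in the source may bear on it.

Measured in an assay on HEK293 cells for inhibition of N-acylethanolamine-hydrolyzing acid amidase (Rattus norvegicus), read by LC-MS, with a stated time of 30 min; a higher number here means a weaker inhibitor, a lower number a stronger inhibitor:
- compound 1, `Cc1cccc(CCCCCCC(=O)N2CCCC2)c1`: 8300 nM
- compound 2, `O=C(CCCCCCc1ccccc1F)N1CCCC1`: 13700 nM
- compound 3, `Cc1ccccc1-c1ccc(CCC(=O)N2CCCC2)cc1`: > 100000 nM (a limit)

Compound 1 and compound 2, both carrying a seven-carbon chain between the aromatic ring and the amide, give measurable numbers in this assay. For the measured compounds named here, compound 3, with a two-carbon chain and a second aromatic ring, reaches only the limit of the assay, > 100000 nM; this is a limit, not a number, and compound 3 is therefore the only compound here without a measured value, as the limit of > 100000 nM in this assay, at which 1 of the 3 values shown sits, records.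

Compound 4 `O=C(CCc1ccc(-c2ccccc2Cl)cc1)N1CCCC1` keeps the whole core of compound 3 and differs from it in one place: chloro in place of methyl on an aromatic carbon. Going by the values given here, no step between measured compounds covers a change of this kind. Since compound 3 sits at the assay limit, no step beyond the scatter is expected from compound 3 to compound 4, with a step that the limit leaves unreadable from compound 3 to compound 4 as the expected step. Compound 4 is estimated at 150000 nM, in the range 40000 nM to 600000 nM, most likely reported again as a limit.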

Compound 4, half-maximal inhibitory concentration: > 100000 nM
Compound 4: a limit, no number; the forecaster's own chance of this, stated with the estimate: 75%; the middle value does not contradict the limit.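

No step can be read from compound 3 to compound 4 in this assay: each is recorded only as a limit, not a number. The compounds shown leave open how chloro and methyl compare on this core.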